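The source may hold more compounds than are shown below. What is called first, only, known or untested is meant among the compounds shown, and "the series" means these compounds.

Compound 1 `O=C(Nc1ccc(-c2cnc3ccccn23)cc1)c1ccc([N+](=O)[O-])o1` and compound 2 `COc1ccn2c(-c3ccc(NC(=O)c4ccc([N+](=O)[O-])o4)cc3)cnc2c1` share one core and differ only at one aromatic carbon. In an ADME assay on microsomes from liver (Homo sapiens) for metabolic stability (on this read-out lower numbers stand for slow clearance and higher numbers for fast clearance), compound 1 gives 85.1 mL.min-1.g-1, and compound 2 gives 74.2 mL.min-1.g-1, the lower of the two numbers shown, though the pair differ by a 1.1-fold lower number from compound 1 to compound 2 (0.06 log units; within the scatter), so the two stand together within the scatter.

Compound 3 `COc1ccn2c(-c3ccc(NC(=O)c4ccc([N+](=O)[O-])o4)c(C(F)(F)F)c3)cnc2c1` carries the change (trifluoromethyl in place of hydrogen on an aromatic carbon). Among the compounds with values here, no measured step covers this change: the only step in hand, methoxy in place of hydrogen on an aromatic carbon, is a different group at a different place and was itself within the scatter. There is therefore no basis in these numbers for expecting a step beyond the scatter in this assay in either direction.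

Compound 3 is accordingly expected to give about 70 mL.min-1.g-1 in this assay, with a range from 35 mL.min-1.g-1 to 140 mL.min-1.g-1. That estimate means a step of a 1.1-fold lower number from compound 2 to compound 3 (0.03 log units; within the scatter), which is expected to lie within the scatter.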

Compound 3, intrinsic clearance in microsomes: 86.7 mL.min-1.g-1
Compound 3: middle estimate off by 1.2-fold (0.09 log units), on the low side; low and high end bracket the measured number.
By their numbers in this assay, from the lowest: compounds 2, 1 and 3 (each within the scatter of the next).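

In this assay the position on the six-membered aromatic ring of carbon only, ortho to a large group and meta to a large group, now has a measured change: trifluoromethyl in place of hydrogen gives a 1.2-fold higher number from compound 2 to compound 3 (0.07 log units; within the scatter) and so leaves clearance where it was within the scatter. Within the data shown here, the earlier pair spoke only to methoxy at a different place, so this is the first reading for this position, and the shared core again shows no step beyond the scatter. Nothing available here offers an explanation for this result.

Going by these compounds, whether an amine, a carboxylic acid or a longer chain at this same position would also stay within the scatter remains open. Also open, on these data alone, is whether trifluoromethyl would give a similar step on a core without the methoxy group.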